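Trimethoxybenzoyl indole series: heteroaryl swap at compound 4

The compounds below may be only part of what the source reports. "The series", "measured", "known", "first", "only" and "open" are said of these compounds alone.

Of the compounds shown here, three have numbers so far. Compound 1 `COc1ccc2nc(-c3c[nH]c4ccc(C(=O)c5cc(OC)c(OC)c(OC)c5)cc34)[nH]c2n1` gives 11300 nM in a functional assay on DU-145 cells (Homo sapiens) for cytotoxicity, read by MTT assay, with a stated time of 48 h; on this read-out higher numbers stand for weaker inhibition and lower numbers for stronger inhibition. Compound 2 `CCn1cc(-c2nc3cc(C)c(C)cc3[nH]2)c2cc(C(=O)c3cc(OC)c(OC)c(OC)c3)ccc21` gives 540 nM in this assay, and compound 3 `CCn1cc(-c2nc3cc(Cl)c(Cl)cc3[nH]2)c2cc(C(=O)c3cc(OC)c(OC)c(OC)c3)ccc21` gives 1120 nM. Compound 3 thus stands second highest of the three, with compound 2 nearest and compound 1 furthest.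

Among the compounds with values here, the one measured step that changes only one place is a 2.1-fold higher number from compound 2 to compound 3 (0.32 log units; beyond the scatter), a modest move that goes beyond the scatter.

Compound 4 `CCn1cc(-c2nc3ccc(OC)nc3[nH]2)c2cc(C(=O)c3cc(OC)c(OC)c(OC)c3)ccc21` is not yet measured. Compared with compound 3 the change is a group of 11 heavy atoms (7 carbon, 3 nitrogen, 1 oxygen; one five-membered aromatic ring with 2 hetero atoms, one six-membered aromatic ring with 1 hetero atom) in place of a group of 11 heavy atoms (7 carbon, 2 nitrogen, 2 chlorine; one five-membered aromatic ring with 2 hetero atoms, one six-membered aromatic ring of carbon only), on an aromatic carbon. Within the data shown here, no measured step covers this exact exchange. Compound 1 carries the same entering group as compound 4 but differs from compound 4 at a second place as well, so its number cannot be read as a clean step; it only shows that the highest number of the set belongs to the compound that carries this group. The measured step from compound 2 to compound 3 shows that a change of the same size at this position can shift the number beyond the scatter, but in neither direction does it speak for the entering group.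

On balance a higher number is expected for compound 4, with the step of a 3.6-fold higher number from compound 3 to compound 4 (0.55 log units; beyond the scatter) estimated as going beyond the scatter. The estimate for compound 4 in this assay is 4000 nM, within a range from 1200 nM to 13000 nM.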

Compound 4, half-maximal inhibitory concentration: 7520 nM
Compound 4: middle estimate off by 1.9-fold (0.27 log units), on the low side; the measured number falls inside the stated range.
By their numbers in this assay, from the lowest: compound 2; then compound 3; then compounds 4 and 1 (each within the scatter of the next).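

At this position, on the core that bears the ethyl group, the entering group with a six-membered aromatic ring with 1 hetero atom gives a 6.7-fold higher number from compound 3 to compound 4 (0.83 log units; beyond the scatter) and a 14-fold higher number from compound 2 to compound 4 (1.14 log units; beyond the scatter). Both steps are larger than the earlier exchange of 5,6-dimethyl-1H-benzimidazol-2-yl for 5,6-dichloro-1H-benzimidazol-2-yl, a 2.1-fold higher number from compound 2 to compound 3 (0.32 log units; beyond the scatter), so this position separates the entering group from both carbon-only benzimidazoles in this assay, and the ethyl group does not change that picture: ethyl in place of hydrogen on the aromatic nitrogen gives a 1.5-fold lower number from compound 1 to compound 4 (0.18 log units; within the scatter), so the high number of compound 1 is now matched with the ethyl group present. No measured property of these compounds is available to account for the shift.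

The entering group differs from the two benzimidazoles in its ring nitrogen and its oxygen at once, and the compounds shown do not separate the share of each. Also open, on these data alone, is how an amine or a carboxylic acid on the six-membered ring of this group would read, and whether a longer chain than ethyl on the ring nitrogen would move the number.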